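This account rests on a few compounds, and the source may have more. Where it says the series, first, only, none or still open, it means among the compounds named here.

Measured so far:
- compound 1, `c1ccc(CCc2ccc3c(NCCCNCc4ccco4)ccnc3c2)cc1`: 9.47
- compound 2, `FC(F)(F)c1cccc(Cc2ccc3c(NCCCNCc4ccco4)ccnc3c2)c1`: 9.47
- compound 3, `COc1cccc(CNCCCNc2ccnc3cc(CCc4ccccc4)ccc23)c1O`: 9.47

These three compounds share a core and were measured in a physicochemical assay for acid dissociation. Compound 1 stands level with compound 2 and compound 3 at the digits shown. Two steps from it have been measured. From compound 1 to compound 2, with 3-(trifluoromethyl)phenyl in place of benzyl on a saturated chain carbon bound to an aromatic carbon, no change at the digits printed from compound 1 to compound 2 (within the scatter). From compound 1 to compound 3, with 2-hydroxy-3-methoxyphenyl in place of furan-2-yl on a saturated chain carbon bound to an amine nitrogen, no change at the digits printed from compound 1 to compound 3 (within the scatter).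

Compound 4, `c1coc(CNCCCNc2ccnc3cc(-c4cccc5ccccc45)ccc23)c1`, has not yet been measured. It differs from compound 1 as follows: naphthalen-1-yl in place of phenethyl on an aromatic carbon. Both measured steps swapped an aromatic group at the edge of the molecule and left this assay unchanged within the scatter, and the change to compound 4 is again a swap of one aromatic group for another. The expected step is therefore none beyond the scatter, no change at the digits printed from compound 1 to compound 4 (within the scatter). For compound 4 the estimate is 9.47, between 9.1 and 9.85.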

Compound 4, acid dissociation constant: 9.47
Estimate against measurement, compound 4: no gap at the digits printed; the range from low to high includes it.
By their numbers in this assay, from the lowest: compounds 1, 2, 3 and 4 (each within the scatter of the next).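

In this assay, naphthalen-1-yl in place of phenethyl on an aromatic carbon gives no change at the digits printed from compound 1 to compound 4 (within the scatter). The earlier steps shown here kept a saturated carbon on this side of the molecule, whereas here the saturated chain is gone, the incoming group sits directly on the aromatic carbon, and the count of six-membered aromatic rings of carbon only in the group rises from one to 2. So in this small set, neither removing that chain nor enlarging the aromatic group moves the reading beyond the scatter, and nothing on hand explains this result.

All the groups varied here on this aromatic carbon contain only carbon and hydrogen, or carry trifluoromethyl. From the compounds shown here alone, whether an amine or a carboxylic acid at this position would leave the reading unchanged remains open, as does the effect of a shorter chain between the core and the furan-2-yl end.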